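The compounds below may be only part of what the source reports. "The series", "measured", "known", "first", "only" and "open" are said of these compounds alone.

Measured so far:

compound 1 `NC1=NC2(CCSCC2)N(OCCCOc2ccc(Cl)c(Cl)c2)C(N)=N1` — 140 nM
compound 2 `NC1=NC2(CCSCC2)N(OCCCOc2cccc(Cl)c2)C(N)=N1` — 260 nM
compound 3 `NC1=NC2(CCOCC2)N(OCCCOc2cccc(Cl)c2Cl)C(N)=N1` — 440 nM

The three measured compounds were run in a functional assay on HL-60 cells (Homo sapiens) for antiproliferative activity, read by MTT assay, with a stated time of 72 h; a higher number here means a weaker inhibitor, a lower number a stronger inhibitor. Compound 1 and compound 2 share one core; compound 3 carries a different core, and the difference between the two cores is not broken down here. Going by the values given here, the one counted step is hydrogen in place of chloro on an aromatic carbon, and for it this assay gives a 1.9-fold higher number from compound 1 to compound 2 (0.27 log units; within the scatter).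

Compound 4 `NC1=NC2(CCOCC2)N(OCCCOc2ccccc2Cl)C(N)=N1` is not yet measured. It differs from compound 3 by hydrogen in place of chloro on an aromatic carbon. Around the place the two cases are not identical: in the pair of compound 1 and compound 2 the carbon is para to a large group, whereas in the pair of compound 3 and compound 4 it is meta to a large group. So this is the same kind of change, not the same change, and there is only one earlier reading of it to lean on.

The expectation for this assay is that compound 4 gives a higher number than compound 3, and the expected step is a 1.8-fold higher number from compound 3 to compound 4 (0.26 log units; within the scatter), set beside the earlier one because the measured pair shows a 1.9-fold higher number from compound 1 to compound 2 (0.27 log units; within the scatter). Given that compound 3 already sits at 440 nM, the estimate for compound 4 is 800 nM, with a plausible range from 400 nM to 1600 nM, the width reflecting that the place is not identical and that a single prior step is the only guide.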

Compound 4, half-maximal inhibitory concentration: 660 nM
Compound 4: middle estimate off by 1.2-fold (0.08 log units), on the high side; low and high end bracket the measured number.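

In this assay, hydrogen in place of chloro on an aromatic carbon gives a 1.5-fold higher number from compound 3 to compound 4 (0.18 log units; within the scatter), and the same kind of change on the other core gives a 1.9-fold higher number from compound 1 to compound 2 (0.27 log units; within the scatter). Set together, the two readings do not differ, so within these two pairs the change carries from one core to the other with no sign that the core alters it: the same change on two cores in this assay, a 1.9-fold higher number (0.27 log units; within the scatter) from compound 1 to compound 2 and a 1.5-fold higher number (0.18 log units; within the scatter) from compound 3 to compound 4, 1.2-fold (0.09 log units) apart, within the scatter of two such steps

This does not show that the chloro group matters for activity, since neither step lies beyond the scatter, and two pairs are too few to support a general rule for the series; the changed carbon also does not stand in the same place in the two pairs, so core and place are not separated.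

Still open, as far as these compounds go, is whether a different group at this place on the ring, such as methoxy, nitrile or trifluoromethyl, would give a step beyond the scatter, which would be a firmer test of carrying a change across cores than the present small steps. Also open, from the compounds shown here alone, is whether the agreement holds for changes elsewhere in the molecule, for example a longer chain joining the ring to the core or an amine on the ring.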